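The source may hold more compounds than are shown below. What is called first, only, known or untested is meant among the compounds shown, and "the series" means these compounds.

In a functional assay on SGC-7901 cells (Homo sapiens) for antiproliferative activity, read by WST assay, with a stated time of 72 h (on this read-out lower numbers stand for stronger inhibition and higher numbers for weaker inhibition), the measurements so far are:
compound 1 (`O=C(CCCCCCn1cc(C(=O)NCc2ccc(Cl)cc2)c2ccccc21)NO`) gives > 100000 nM, a limit of the assay and not a number
compound 2 (`O=C(CCCCCCn1cc(C(=O)NC2CCCCC2)c2ccccc21)NO`) gives 25400 nM

Among the compounds with values here, compound 2 holds the only actual number, 25400 nM, so it is the single firm reference point in this assay for what follows.

Compound 3 (`O=C(CCCCCCn1cc(C(=O)NC2CCCCCCC2)c2ccccc21)NO`) differs from compound 2 in one group, with cyclooctyl in place of cyclohexyl on an amide-type nitrogen.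

Within the data shown here, one measured step bears on this change, at the same kind of nitrogen: an at least 3.9-fold lower number from compound 1 to compound 2 (0.59 log units; beyond the scatter). That step starts from a limit, so its full size is open. It shows that the group on this nitrogen can move the read-out, but it compares a different pair of groups and gives no direction for a change of ring size. A step beyond the scatter is therefore not expected in this assay, with only a slight lean towards a lower number. The estimated step is a 1.4-fold lower number from compound 2 to compound 3 (0.15 log units; within the scatter), and its uncertainty is wide. For compound 3 the expected value is 18000 nM, with an estimated range of 6000 nM to 60000 nM.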

Compound 3, half-maximal inhibitory concentration: 67000 nM
Compound 3: the middle estimate sits 3.7-fold (0.57 log units) below what was measured; the measured number lies above the stated range.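

Ring size on the amide-type nitrogen matters in this assay, even among rings of carbon only: going from the six-membered to the eight-membered ring gives a 2.6-fold higher number from compound 2 to compound 3 (0.42 log units; beyond the scatter), so the larger ring moves the read-out towards weaker inhibition. The earlier step compared a benzyl group with a ring, whereas this one shows that the read-out also responds to a change within the cycloalkyl groups, with cyclohexyl ahead of cyclooctyl. Against the 4-chlorobenzyl group, the change gives an at least 1.4-fold lower number from compound 1 to compound 3 (0.17 log units; that floor lies within the scatter), and since that floor lies within the scatter, cyclooctyl cannot be firmly placed ahead of 4-chlorobenzyl, whose compound 1 value is a limit of the assay and not a number: the limit of > 100000 nM in this assay, at which 1 of the 3 values shown sits.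

Within the data shown here, with only two ring sizes compared, the shape of the trend remains open: cyclopentyl and cycloheptyl on this nitrogen would show whether cyclohexyl sits near a best size or whether a smaller ring does better. From the compounds shown here alone, it is also open how a ring carrying an amine or a hydroxyl group would compare with these carbon-only rings.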